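Side-chain amine swap at the aryl ether chain

The source may hold more compounds than are shown below. What is called first, only, known or untested is meant among the compounds shown, and "the series" means these compounds.

Measured in a functional assay on NCI-H661 cells (Homo sapiens) for cytotoxicity, read by WST assay, with a stated time of 72 h; a higher number here means a weaker inhibitor, a lower number a stronger inhibitor:
compound 1 `COc1cc2c(Nc3nc4ccc(C(=O)Nc5c(C)cccc5Cl)cc4s3)ncnc2cc1OCCCN1CCCCC1C` gives 5300 nM
compound 2 `COc1cc2c(Nc3nc4ccc(C(=O)Nc5c(C)cccc5C)cc4s3)ncnc2cc1OCCCN1CCCCC1C` gives 84400 nM
compound 3 `COc1cc2c(Nc3nc4ccc(C(=O)Nc5c(C)cc(C)cc5C)cc4s3)ncnc2cc1OCCCN1CCCCC1C` gives 8800 nM

Compound 3 stands second highest of the three numbers in this assay. The step of a 1.7-fold higher number from compound 1 to compound 3 (0.22 log units; within the scatter) leaves compound 3 and compound 1 within the scatter of each other, whereas the step of a 9.6-fold lower number from compound 2 to compound 3 (0.98 log units; beyond the scatter) sets it apart from compound 2, as a 16-fold higher number from compound 1 to compound 2 (1.20 log units; beyond the scatter) does for compound 1. All three measured steps concern the substituent on the amide nitrogen. Compound 4 `COc1cc2c(Nc3nc4ccc(C(=O)Nc5c(C)cc(C)cc5C)cc4s3)ncnc2cc1OCCCN1CCCC1` differs from compound 3 elsewhere: pyrrolidin-1-yl in place of 2-methylpiperidin-1-yl on a saturated chain carbon, three bonds along the chain from an oxygen on an aromatic ring. Among the measured compounds shown here, no measured step touches this part of the molecule, so nothing beyond the scatter in this assay is expected in either direction. The expected step is no change at the digits printed from compound 3 to compound 4 (within the scatter). Compound 4 is therefore estimated at 8800 nM, with a range of 3000 nM to 26000 nM.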

Compound 4, half-maximal inhibitory concentration: 9600 nM
Compound 4: middle estimate off by 1.1-fold (0.04 log units), on the low side, within the range that was stated.
By their numbers in this assay, from the lowest: compounds 1, 3 and 4 (each within the scatter of the next); then compound 2.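

In this assay, among the compounds shown here, pyrrolidin-1-yl in place of 2-methylpiperidin-1-yl gives a 1.1-fold higher number from compound 3 to compound 4 (0.04 log units; within the scatter) and is the first step read away from the amide substituent. With 2,4,6-trimethylphenyl on the amide nitrogen, this place on the saturated chain carbon accepts the five-membered ring without the methyl and without a step beyond the scatter. No evidence bears on this result.

On these data alone, whether morpholin-4-yl, dimethylamino or a shorter chain fits equally remains open. So does whether the same swap holds with 2-chloro-6-methylphenyl or 2,6-dimethylphenyl on the amide nitrogen.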